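Swapping the Chain Amine on an Aryl Amide Series

The source may hold more compounds than are shown below. What is called first, only, known or untested is meant among the compounds shown, and "the series" means these compounds.

Two measured compounds frame this step. Compound 1 `COc1cc2c(Oc3ccc(NC(=O)c4nn(-c5ccccc5C)c(=O)cc4C)cc3F)ccnc2cc1OCCCN1CCN(C)CC1` gives 2830 nM in a functional assay on A549 cells (Homo sapiens) for inhibition, read by MTT assay, with a stated time of 72 h (a lower number here means a stronger inhibitor, a higher number a weaker inhibitor), while compound 2 `COc1cc2c(Oc3ccc(NC(=O)c4nn(-c5ccccc5OC(F)(F)F)c(=O)cc4C)cc3F)ccnc2cc1OCCCN1CCCCC1` gives 120 nM in this assay, the lowest of the two numbers, with a gap to compound 1 that lies beyond the usual scatter. Compound 3 `COc1cc2c(Oc3ccc(NC(=O)c4nn(-c5ccccc5OC(F)(F)F)c(=O)cc4C)cc3F)ccnc2cc1OCCCN1CCN(C)CC1` differs from compound 2 by 4-methylpiperazin-1-yl in place of piperidin-1-yl on a saturated chain carbon, three bonds along the chain from an oxygen on an aromatic ring. For the measured compounds named here, no measured pair isolates this change, so the step is expected to be modest, a 1.7-fold higher number from compound 2 to compound 3 (0.22 log units; within the scatter), if anything toward a higher number. Compound 3 is therefore estimated at 200 nM, with a range from 60 nM to 700 nM.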

Compound 3, half-maximal inhibitory concentration: 130 nM
Compound 3: middle estimate off by 1.5-fold (0.19 log units), on the high side, within the range that was stated.
By their numbers in this assay, from the lowest: compounds 2 and 3 (each within the scatter of the next); then compound 1.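

In this assay, 4-methylpiperazin-1-yl in place of piperidin-1-yl at the end of the chain gives a 1.1-fold higher number from compound 2 to compound 3 (0.03 log units; within the scatter), so this position tolerates either amine with the trifluoromethoxy group present. With the chain amine held constant, trifluoromethoxy in place of methyl on an aromatic carbon gives a 22-fold lower number from compound 1 to compound 3 (1.34 log units; beyond the scatter), which places the large gap on the aromatic substituent rather than on the amine. Nothing available explains either step. The compounds shown leave open whether a morpholine or a dimethylamino group would read the same on this chain, and whether a methoxy or chlorine would hold the aromatic gain.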